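A few compounds are considered here, and "the series" means these few. Any claim that something is new, unique, unknown or untested is made for them only; others in the source may bear on it.

Three compounds have been measured in an assay on HEK293 cells for agonist activity at transient receptor potential cation channel subfamily M member 8 (Homo sapiens), read by fluorescence and calcium flux, with a stated time of 15 min; a higher number here means that more compound is needed for the effect, a lower number that less compound is needed:

Compound 1, `Cc1ccc(OCC(=O)N(Cc2cccs2)C2COC2)cc1`, gives 23000 nM.
Compound 2, `Cc1ccc(OCC(=O)N(Cc2cccs2)c2ccncc2)cc1`, gives 52 nM.
Compound 3, `Cc1ccc(OCC(=O)N(Cc2cccs2)c2nccs2)cc1`, gives 2240 nM.

All three share the same core and differ only in the group carried on the amide-type nitrogen. Compound 3 holds the second highest of the three numbers: compound 1 lies above it, as the step of a 10-fold lower number from compound 1 to compound 3 (1.01 log units; beyond the scatter) shows, while compound 2 lies far below it, as the step of a 43-fold higher number from compound 2 to compound 3 (1.63 log units; beyond the scatter) shows.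

Compound 4, `Cc1ccc(OCC(=O)N(Cc2cccs2)c2cnccn2)cc1`, has not yet been measured. It differs from compound 3 in a single place: pyrazin-2-yl in place of 1,3-thiazol-2-yl on an amide-type nitrogen.

Among the measured compounds shown here, two measured steps bear on this change. The step of a 43-fold higher number from compound 2 to compound 3 (1.63 log units; beyond the scatter) shows that swapping pyridin-4-yl for 1,3-thiazol-2-yl raised the number strongly, and the step of a 10-fold lower number from compound 1 to compound 3 (1.01 log units; beyond the scatter) shows that 1,3-thiazol-2-yl in turn needs far less compound than oxetan-3-yl. The incoming pyrazin-2-yl is, like pyridin-4-yl, one six-membered aromatic ring, yet it carries 2 hetero atoms as 1,3-thiazol-2-yl does, so a move back toward compound 2 is expected, probably without reaching it. Compound 4 is therefore estimated to give 400 nM, within 70 nM to 2500 nM. This estimate corresponds to an expected step of a 5.6-fold lower number from compound 3 to compound 4 (0.75 log units; beyond the scatter).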

Compound 4, half-maximal effective concentration: 1240 nM
The estimate for compound 4 lay 3.1-fold (0.49 log units) below the measured number; measured number inside the range.
By their numbers in this assay, from the lowest: compound 2; then compounds 4 and 3 (each within the scatter of the next); then compound 1.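

In this assay, replacing the five-membered 1,3-thiazol-2-yl with the six-membered pyrazin-2-yl gives a 1.8-fold lower number from compound 3 to compound 4 (0.26 log units; within the scatter), which lies within the scatter, so in this pair a change of ring size, with two hetero atoms in both rings, makes no clear difference. Among the compounds shown here, a six-membered aromatic ring on the amide-type nitrogen is therefore not enough to match pyridin-4-yl, as a 24-fold higher number from compound 2 to compound 4 (1.38 log units; beyond the scatter) shows, and this separates ring size from the large gap that compound 2 opened in the earlier steps. The step of a 19-fold lower number from compound 1 to compound 4 (1.27 log units; beyond the scatter) adds a second aromatic ring that needs far less compound than oxetan-3-yl, although neither it nor 1,3-thiazol-2-yl comes close to pyridin-4-yl.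

No measurement shown here explains why pyridin-4-yl stands so far apart from the other groups. As far as these compounds go, it also remains open whether a plain phenyl ring, with no nitrogen in the ring, or a pyrimidine ring on the same nitrogen would fall with compound 2 or with compound 3 and compound 4.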